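The source may hold more compounds than are shown below. What is called first, only, known or untested is meant among the compounds shown, and "the series" means these compounds.

In a functional assay on the whole organism for inhibition, with Rattus norvegicus as the target, with a stated time of 1 h (on this read-out higher numbers stand for an effect only at larger amounts of compound and lower numbers for an effect already at smaller amounts), compound 2 `Cc1nc2c(/C=C\c3ccccc3)cccn2c1N` gives 23 mg/kg, the highest of the two numbers recorded; the nearest is compound 1 `Cc1nc2c(/C=C/c3ccccc3)cccn2c1C`, which gives 10.4 mg/kg in this assay, a gap beyond the scatter. Compound 3 `Cc1nc2c(/C=C/c3ccccc3)cccn2c1N` has not yet been measured. It differs from compound 2 in that (the two compounds have the same atoms and bonds and differ only in configuration as drawn: 1 of 1 stereo elements differ; a double bond is drawn Z in compound 2 and E in compound 3). Among the measured compounds shown here, no measured pair isolates this change, so the step from compound 2 to compound 3 is uncertain; the account expects a modest move toward lower dose, about a 1.9-fold lower number from compound 2 to compound 3 (0.28 log units; within the scatter), near the edge of the scatter. Compound 3 is therefore estimated at 12 mg/kg, within 5 mg/kg to 30 mg/kg.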

Compound 3, dose for half-maximal effect: 13 mg/kg
For compound 3 the middle estimate is 1.1-fold (0.03 log units) below the measured one; the range from low to high includes it.
By their numbers in this assay, from the lowest: compounds 1, 3 and 2 (each within the scatter of the next, the first and the last beyond it).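

In this assay the configuration of the double bond now has a measured pair of its own, and the step is a 1.8-fold lower number from compound 2 to compound 3 (0.25 log units; within the scatter), so Z and E are not told apart here: the fact that compounds 2 and 3 differ only in the configuration as drawn. With the E double bond held, amino in place of methyl on an aromatic carbon gives a 1.3-fold higher number from compound 1 to compound 3 (0.10 log units; within the scatter). Neither single change alone moves the number beyond the scatter. The compounds shown leave open whether a longer chain or a carboxylic acid in the place of that amino group would do so.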